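Methylsulfonyl for dimethylcarbamoyl: half-life outlook for compound 4

A few compounds are considered here, and "the series" means these few. Any claim that something is new, unique, unknown or untested is made for them only; others in the source may bear on it.

Of the compounds shown here, three on the shared core have been measured in an in vivo ADME assay on the whole organism for metabolic stability, with Rattus norvegicus as the target, at a dose of 1 mg/kg by the intravenous route; on this read-out higher numbers stand for a longer-lived compound and lower numbers for a shorter-lived compound. Compound 1 `CN(Cc1ncc2ccccc2c1CNC(=N)N)[C@H]1CCCc2cccnc21` gives 12 h. Compound 2 `CN(C)CC(=O)NCc1c(CN(C)[C@H]2CCCc3cccnc32)ncc2ccccc12` gives 1.5 h. Compound 3 `CN(C)C(=O)NCCCc1c(CN(C)[C@H]2CCCc3cccnc32)ncc2ccccc12` gives 3.1 h, the middle of the three numbers and beyond the scatter from each of the other two.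

Compound 4 `CN(Cc1ncc2ccccc2c1CCCNS(C)(=O)=O)[C@H]1CCCc2cccnc21` differs from compound 3 as follows: methylsulfonyl in place of dimethylcarbamoyl on an amine nitrogen. In words, methylsulfonyl stands in place of dimethylcarbamoyl on an amine nitrogen. Within the data shown here, no measured step makes this exchange, so the evidence is indirect.

The two steps away from compound 1, an 8.0-fold lower number from compound 1 to compound 2 (0.90 log units; beyond the scatter) and a 3.9-fold lower number from compound 1 to compound 3 (0.59 log units; beyond the scatter), each replace a whole group and bear on this exchange only loosely. The closest guide is a 2.1-fold higher number from compound 2 to compound 3 (0.32 log units; beyond the scatter), the smallest of the three steps and still a larger edit, as it alters the 2-((dimethylcarbamoyl)amino)ethyl group as a whole. Compound 4 changes only the end of that group, so no step beyond the scatter is expected in this assay, and no direction can be favoured. The expected change is a 1.0-fold lower number from compound 3 to compound 4 (0.01 log units; within the scatter). For compound 4 the estimate is 3 h, with an expected range of 1.5 h to 6 h.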

Compound 4, half-life: 5.8 h
Compound 4: middle estimate off by 1.9-fold (0.29 log units), on the low side; measured number inside the range.
By their numbers in this assay, from the lowest: compound 2; then compounds 3 and 4 (each within the scatter of the next); then compound 1.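

Read in this assay, methylsulfonyl in place of dimethylcarbamoyl on an amine nitrogen gives a 1.9-fold higher number from compound 3 to compound 4 (0.27 log units; within the scatter), the first direct reading of this exchange, and on this chain the half-lives of the two end groups are not told apart. Compound 4 stands clear of the other two compounds on both sides, with a 3.9-fold higher number from compound 2 to compound 4 (0.59 log units; beyond the scatter) and a 2.1-fold lower number from compound 1 to compound 4 (0.32 log units; beyond the scatter), so the middle place held by compound 3 survives the exchange, although both of these steps alter more than the end group. Nothing measured here bears on what lies behind these half-lives.

The compounds shown leave open whether the same amine nitrogen keeps this half-life with other end groups, such as acetyl or a larger sulfonyl group like phenylsulfonyl. They also leave open how the half-life responds to chain length with the end group held fixed, for example in a compound carrying (methanesulfonamido)methyl or a longer chain ending in methanesulfonamido on the shared core.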